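Benzyloxy anilines on a crown-fused core: nitro for trifluoromethyl

A few compounds are considered here, and "the series" means these few. Any claim that something is new, unique, unknown or untested is made for them only; others in the source may bear on it.

Measured compounds:
compound 1 `FC(F)(F)c1ccc(COc2cccc(Nc3ncnc4cc5c(cc34)OCCOCCO5)c2)cc1`, > 100000 nM
compound 2 `O=[N+]([O-])c1ccc(COc2ccc(Nc3ncnc4cc5c(cc34)OCCOCCOCCOCCO5)cc2)cc1`, > 100000 nM

In a functional assay on DU-145 cells (Homo sapiens) for antiproliferative activity, read by MTT assay, with a stated time of 72 h (a higher number here means a weaker inhibitor, a lower number a stronger inhibitor), compound 1 gives > 100000 nM, which is a limit of the assay rather than a number. Compound 2 likewise gives > 100000 nM, again a limit. So compound 1 stands at the limit: the limit of > 100000 nM in this assay, at which 2 of the 2 values shown sit. Neither compound yields a numeric reading.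

Compound 3 `O=[N+]([O-])c1ccc(COc2cccc(Nc3ncnc4cc5c(cc34)OCCOCCO5)c2)cc1` is the next member. The change from compound 1 to compound 3 is nitro in place of trifluoromethyl on an aromatic carbon, in words nitro in place of trifluoromethyl on an aromatic carbon. Among the compounds with values here, no measured pair isolates this change. Compound 2 also carries the nitro group, and its value shows no activity within the range of the assay, though its core and substitution pattern differ in other ways as well.

The expected step of a number no higher from compound 1 to compound 3 (the limit leaves the size open) is therefore none beyond the scatter, with the result most likely again a limit. For compound 3 the estimate is 100000 nM, between 30000 nM and 300000 nM.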

Compound 3, half-maximal inhibitory concentration: > 100000 nM
Compound 3: a limit, no number; the forecaster's own chance of this, stated with the estimate: 75%; the middle value sits exactly at the limit.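

No step can be read from compound 1 to compound 3, since both values are limits and not numbers: the limit of > 100000 nM in this assay, at which 3 of the 3 values shown sit.

The compounds shown leave open whether nitro in place of trifluoromethyl on an aromatic carbon alters antiproliferative activity at all; none of them gives a numeric reading.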